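Cytotoxicity notes: amide-side variation on the shared core

A few compounds are considered here, and "the series" means these few. Any claim that something is new, unique, unknown or untested is made for them only; others in the source may bear on it.

Compound 3 `Cc1cc(C#N)cc(C)c1Oc1nc(Nc2ccc(C#N)cc2)ncc1/C=C/C(=O)NCC1CCN(S(C)(=O)=O)CC1` carries a ((1-(methylsulfonyl)piperidin-4-yl)methyl)amino group on the carbonyl carbon of the shared core. In an ADME assay on TZM cells (Homo sapiens) for cytotoxicity, with a stated time of 1 days (a higher number here means that more compound is tolerated, a lower number that less compound is tolerated), compound 3 gives > 171 nM, which is a limit of the assay and not a number. Its two neighbours are limits as well. Compound 1 `Cc1cc(C#N)cc(C)c1Oc1nc(Nc2ccc(C#N)cc2)ncc1/C=C/C(N)=O` gives > 243 nM in this assay, a limit. Compound 2 `COCCNC(=O)/C=C/c1cnc(Nc2ccc(C#N)cc2)nc1Oc1c(C)cc(C#N)cc1C` gives > 213 nM in this assay, again a limit. All three values thus sit at limits (the limit of > 171 nM in this assay, at which 1 of the 3 values shown sits, (the limit of > 213 nM in this assay, at which 1 of the 3 values shown sits), (the limit of > 243 nM in this assay, at which 1 of the 3 values shown sits)), so a step that the two limits leave unreadable from compound 1 to compound 2, a step that the two limits leave unreadable from compound 1 to compound 3 and a step that the two limits leave unreadable from compound 2 to compound 3 stay hidden behind them; none can be sized.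

Compound 4 `Cc1cc(C#N)cc(C)c1Oc1nc(Nc2ccc(C#N)cc2)ncc1/C=C/C(=O)N1CCN(C(=O)C(F)(F)F)CC1` differs from compound 3 by 4-((trifluoromethyl)carbonyl)piperazin-1-yl in place of ((1-(methylsulfonyl)piperidin-4-yl)methyl)amino on a carbonyl carbon. The three measured steps all touch the amide side of the core and so bear on this change, but each is unreadable, leaving no measured guide to its size. Nothing beyond the scatter is expected in this assay, with a limit again the most likely report, so the expected step that the limit leaves unreadable from compound 3 to compound 4 is essentially none. Compound 4 is therefore estimated at 200 nM, in the range 100 nM to 400 nM.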

Compound 4, half-maximal cytotoxic concentration: > 174 nM
Compound 4: no number, only a limit; the forecaster's own chance of this, stated with the estimate: 80%; the middle value is on the limit's open side.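

In this assay compound 4 gives > 174 nM, a limit of the assay and not a number. Its steps from compound 1, compound 2 and compound 3 cannot be read. The compounds shown leave open where the half-maximal cytotoxic concentration of any of the four lies, and whether the amide side changes it at all.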